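Replacing Hydroxy with Dimethylamino in a Cytotoxic Series

The compounds below may be only part of what the source reports. "The series", "measured", "known", "first", "only" and "open" are said of these compounds alone.

In a functional assay on HCT-116 cells (Homo sapiens) for cytotoxicity, read by MTT assay, with a stated time of 48 h (on this read-out lower numbers stand for stronger inhibition and higher numbers for weaker inhibition), compound 1 `COc1cc(/C=C/C(=O)C2=C(/C=C/c3ccc(O)c(OC)c3)NC(=O)NC2c2ccccc2)ccc1O` gives 25000 nM, compound 2 `COc1cc(/C=C/C(=O)C2=C(/C=C/c3ccc(O)c(OC)c3)NC(=O)NC2c2ccc(C)cc2)ccc1O` gives 12500 nM, and compound 3 `COc1cc(/C=C/C(=O)C2=C(/C=C/c3ccc(O)c(OC)c3)NC(=O)NC2c2ccc(O)cc2)ccc1O` gives 100000 nM, the highest number of the three and so the weakest result. Compound 4 `COc1cc(/C=C/C(=O)C2=C(/C=C/c3ccc(O)c(OC)c3)NC(=O)NC2c2ccc(N(C)C)cc2)ccc1O` carries dimethylamino in place of hydroxy on an aromatic carbon. Within the data shown here, no dimethylamino compound has been measured, so the nearest guides are three other steps. Hydroxy in place of hydrogen gave a 4.0-fold higher number from compound 1 to compound 3 (0.60 log units; beyond the scatter), hydroxy in place of methyl gave an 8.0-fold higher number from compound 2 to compound 3 (0.90 log units; beyond the scatter), and methyl in place of hydrogen gave a 2.0-fold lower number from compound 1 to compound 2 (0.30 log units; within the scatter). Losing the hydroxy may therefore undo that rise, and the expected change is a 4.0-fold lower number from compound 3 to compound 4 (0.60 log units; beyond the scatter). For compound 4 the estimated value is 25000 nM, with an expected range of 8000 nM to 70000 nM.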

Compound 4, half-maximal inhibitory concentration: 12500 nM
Beside the measured number, compound 4's estimate is 2.0-fold (0.30 log units) above it; measured number inside the range.
By their numbers in this assay, from the lowest: compounds 2, 4 and 1 (each within the scatter of the next); then compound 3.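

In this assay the change gives an 8.0-fold lower number from compound 3 to compound 4 (0.90 log units; beyond the scatter) and shows that this position tolerates a group of more heavy atoms than hydroxy without any loss. Measured against the other two, dimethylamino gives a 2.0-fold lower number from compound 1 to compound 4 (0.30 log units; within the scatter) and no change at the digits printed from compound 2 to compound 4 (within the scatter) so hydrogen, methyl and dimethylamino all read alike here, and among these four compounds only hydroxy stands apart. Nothing available explains why hydroxy differs. On these data alone, whether a plain amino group, a methoxy group or a carboxylic acid at this position would read like hydroxy or like the other three stays open.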